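Switching the ring for an ether on the trifluoromethyl ring

A few compounds are considered here, and "the series" means these few. Any claim that something is new, unique, unknown or untested is made for them only; others in the source may bear on it.

The measured compounds:
Compound 1 `CC(C(=O)NCc1ccc(C(F)(F)F)cc1N1CCCC1)c1ccc(NS(C)(=O)=O)c(F)c1` gives 2.3 nM in an assay on CHO cells for antagonist activity at transient receptor potential cation channel subfamily V member 1 (Homo sapiens), read by FLIPR; a higher number here means a weaker inhibitor, a lower number a stronger inhibitor.
Compound 2 `CCC1CCN(c2cc(C(F)(F)F)ccc2CNC(=O)C(C)c2ccc(NS(C)(=O)=O)c(F)c2)CC1` gives 0.7 nM in this assay.

For the measured compounds named here, compound 2 stands at the lowest of the two numbers in this assay; its nearest neighbour is compound 1, and the change a 3.3-fold lower number from compound 1 to compound 2 (0.52 log units; beyond the scatter) is the only step so far, a modest one beyond the scatter.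

Compound 3 `CC(C)COc1cc(C(F)(F)F)ccc1CNC(=O)C(C)c1ccc(NS(C)(=O)=O)c(F)c1` is not yet measured. It differs from compound 2 by isobutoxy in place of 4-ethylpiperidin-1-yl on an aromatic carbon. Going by the values given here, the one step that bears on it is the one from compound 1 to compound 2, where a group with one ring was exchanged for a larger group with one ring and the number fell. Among the compounds with values here, the change to compound 3 goes the other way in the count of atoms, and also removes the ring; no measured pair shows this kind of exchange directly, so the step from compound 2 to compound 3 can only be guessed from the size of the earlier one. Compound 3 is therefore expected to give a number somewhat higher than compound 2, a step of about a 2.9-fold higher number from compound 2 to compound 3 (0.46 log units; beyond the scatter), and its estimate in this assay is 2 nM, with a range from 0.6 nM to 7 nM.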

Compound 3, inhibition constant: 0.8 nM
Compound 3: the middle estimate sits 2.5-fold (0.40 log units) above what was measured; the measured number falls inside the stated range.
By their numbers in this assay, from the lowest: compounds 2 and 3 (each within the scatter of the next); then compound 1.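

In this assay the step is a 1.1-fold higher number from compound 2 to compound 3 (0.06 log units; within the scatter), so on this aromatic carbon, ortho to a large group and meta to a trifluoromethyl group, the open-chain isobutoxy with its 5 heavy atoms reads the same as 4-ethylpiperidin-1-yl with its 8 heavy atoms and its six-membered ring. Against the pyrrolidin-1-yl of compound 1, the same ether gives a 2.9-fold lower number from compound 1 to compound 3 (0.46 log units; beyond the scatter), so among these three compounds neither a ring nor a nitrogen on this carbon is needed to reach the lowest numbers seen here. Nothing given here accounts for why the ether and the piperidine read alike.

The compounds shown hold only one ether, so it stays open whether a shorter chain such as methoxy, a longer chain such as hexyloxy, or a cyclic ether such as tetrahydropyranyloxy would read the same at this position. Also open, from the compounds shown here alone, is whether an open-chain amine such as diethylamino, which keeps the nitrogen but drops the ring, would match isobutoxy, and whether the match between compound 2 and compound 3 holds in any other read-out.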